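This account rests on a few compounds, and the source may have more. Where it says the series, first, only, none or still open, it means among the compounds named here.

Compound 1, `O=C(Nc1ccccc1[N+](=O)[O-])c1ccc(/N=N\c2c[nH]c3ccccc23)cc1`: in a functional assay on MCF7 cells (Homo sapiens) for inhibition, read by MTT assay, with a stated time of 72 h (a higher number here means a weaker inhibitor, a lower number a stronger inhibitor), compound 1 gives 101000 nM.
Compound 2, `COc1ccccc1NC(=O)c1ccc(/N=N\c2c[nH]c3ccccc23)cc1`: in this assay compound 2 gives 86500 nM.

Going by the values given here, of the two numbers so far, compound 2 holds the lowest, but its nearest neighbour is compound 1, and the step of a 1.2-fold lower number from compound 1 to compound 2 (0.07 log units; within the scatter) stays within the scatter, so the two are not separable on these data. Compound 3, `Cc1ccccc1NC(=O)c1ccc(/N=N\c2c[nH]c3ccccc23)cc1`, has not yet been measured. It differs from compound 2 in one place: methyl in place of methoxy on an aromatic carbon. Among the compounds with values here, the only measured step that bears on a change at this position is the one from compound 1 to compound 2, which exchanged a nitro for a methoxy on that same aromatic carbon and moved the number by no more than the scatter. On that basis the step of a 1.0-fold higher number from compound 2 to compound 3 (0.02 log units; within the scatter) is expected to be small, with no direction beyond the scatter. Compound 3 is therefore estimated at 90000 nM in this assay, with a range from 45000 nM to 180000 nM.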

Compound 3, half-maximal inhibitory concentration: 73400 nM
Beside the measured number, compound 3's estimate is 1.2-fold (0.09 log units) above it; the range from low to high includes it.
By their numbers in this assay, from the lowest: compounds 3, 2 and 1 (each within the scatter of the next).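

In this assay, a third group on this aromatic carbon still gives no separation: methyl in place of methoxy gives a 1.2-fold lower number from compound 2 to compound 3 (0.07 log units; within the scatter) and methyl in place of nitro gives a 1.4-fold lower number from compound 1 to compound 3 (0.14 log units; within the scatter), so nitro, methoxy and methyl cannot be told apart here. The change to methyl also goes from two heavy atoms to one and from one hydrogen-bond acceptor to none, and neither difference yields a step beyond the scatter. Nothing available explains why these groups cannot be told apart.

The compounds shown leave open whether an amine, a carboxylic acid or a longer chain on this carbon would stand apart from these three. They also leave open whether any of these groups would behave the same way on another carbon of that ring.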